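Trifluoromethyl phenyl urea from the fluoro semicarbazide lead

A few compounds are considered here, and "the series" means these few. Any claim that something is new, unique, unknown or untested is made for them only; others in the source may bear on it.

Values in a functional assay on NCI-H460 cells (Homo sapiens) for inhibition, read by MTT assay, with a stated time of 72 h; on this read-out higher numbers stand for weaker inhibition and lower numbers for stronger inhibition:
- compound 1 `COc1cc(NC(C)CCCNC(=O)NNC(=O)Nc2ccc(F)cc2)c2ncccc2c1`: > 100000 nM
- compound 2 `COc1cc(NC(C)CCCNC(=O)NNC(=O)Nc2ccc(C(F)(F)F)cc2)c2ncccc2c1`: 12000 nM
- compound 3 `COc1cc(NC(C)CCCNC(=O)Nc2cc(C(F)(F)F)cc(C(F)(F)F)c2)c2ncccc2c1`: 8300 nM

Compound 1 has no number, only a limit: it stands at the limit of > 100000 nM in this assay, at which 1 of the 3 values shown sits. The next compound to be measured is compound 4 `COc1cc(NC(C)CCCNC(=O)Nc2ccc(C(F)(F)F)cc2)c2ncccc2c1`. The change from compound 1 is 4-(trifluoromethyl)phenyl in place of ((4-fluorophenyl)carbamoyl)amino on an amide-type nitrogen.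

Going by the values given here, the one measured step bearing on this is an at least 8.3-fold lower number from compound 1 to compound 2 (0.92 log units; beyond the scatter), with trifluoromethyl in place of fluoro on an aromatic carbon. Compound 3 also lacks the ((4-fluorophenyl)carbamoyl)amino group and gives 8300 nM, within the usual scatter of compound 2 at 12000 nM. A step to a lower number of similar size is therefore expected in this assay. The expected step is an at least 10-fold lower number from compound 1 to compound 4 (1.00 log units; beyond the scatter). For compound 4 the estimate is 10000 nM, with an expected range of 3000 nM to 35000 nM.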

Compound 4, half-maximal inhibitory concentration: 24000 nM
Beside the measured number, compound 4's estimate is 2.4-fold (0.38 log units) below it; low and high end bracket the measured number.
By their numbers in this assay, from the lowest: compounds 3, 2 and 4 (each within the scatter of the next, the first and the last beyond it). At a limit, above all of these: compound 1.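

In this assay, 4-(trifluoromethyl)phenyl in place of ((4-fluorophenyl)carbamoyl)amino on the amide-type nitrogen gives an at least 4.1-fold lower number from compound 1 to compound 4 (0.61 log units; beyond the scatter). This step is only a bound, with compound 1 standing at a limit: the limit of > 100000 nM in this assay, at which 1 of the 4 values shown sits. What is new is that the plain urea carrying 4-(trifluoromethyl)phenyl, without the semicarbazide unit, still gives a measurable value: compound 4 gives 24000 nM and compound 2 gives 12000 nM, values within the scatter of each other, so no effect of that unit can be read once trifluoromethyl is present.

As far as these compounds go, how far compound 1 lies past its limit stays unknown, and with it the true size of the step. Also open, from the compounds shown here alone, is whether a chloro, a methoxy or a carboxylic acid on the same phenyl ring of the urea would move the value.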